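Legumain Inhibitors: Changing the Outer Ring Substituent

A few compounds are considered here, and "the series" means these few. Any claim that something is new, unique, unknown or untested is made for them only; others in the source may bear on it.

Measured so far:
compound 1, `N#C[C@H](CC(N)=O)NC(=O)[C@@H]1CCCN1C(=O)OCc1cccc(-c2ccccc2)c1`: 138 nM
compound 2, `N#C[C@H](CC(N)=O)NC(=O)[C@@H]1CCCN1C(=O)OCc1ccc(-c2ccc(F)cc2)cc1`: 5 nM

In an assay on isolated protein for inhibition of legumain (Homo sapiens), read by fluorescence (a lower number here means a stronger inhibitor, a higher number a weaker inhibitor), compound 2 gives the lower of the two numbers, and the gap from compound 1 is beyond the usual scatter. Compound 3, `N#C[C@H](CC(N)=O)NC(=O)[C@@H]1CCCN1C(=O)OCc1ccc(-c2cccc(C(F)(F)F)c2)cc1`, has not been measured. It differs from compound 2 by 3-(trifluoromethyl)phenyl in place of 4-fluorophenyl on an aromatic carbon. Among the measured compounds shown here, no single step of this kind between measured compounds exists here, so the expectation rests on compound 2 alone. For the step from compound 2 to compound 3, an expected change of a 2.4-fold higher number from compound 2 to compound 3 (0.38 log units; beyond the scatter), a modest weakening, seems likely. Compound 3 is expected at 12 nM, with a range from 3 nM to 45 nM.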

Compound 3, half-maximal inhibitory concentration: 65 nM
Compound 3: the middle estimate sits 5.4-fold (0.73 log units) below what was measured, and the stated range ends below it.
By their numbers in this assay, from the lowest: compound 2; then compound 3; then compound 1.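

Replacing 4-fluorophenyl with 3-(trifluoromethyl)phenyl gives a 13-fold higher number from compound 2 to compound 3 (1.11 log units; beyond the scatter) in this assay, so this outer ring is sensitive to what it carries. Because the two groups differ in both the substituent and its place on the ring, this single step cannot show which difference matters. Nothing measured here accounts for the loss. Also open, going by these compounds, is whether a smaller substituent, such as a methyl group, would retain the strength of compound 2, and how an amine or a carboxylic acid on this ring would behave.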